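Swapping a methyl for a methoxy on the hydrazone ring

The source may report more compounds than this note shows. Statements on the series, on what has been measured and on what is new or still open speak of the compounds shown alone.

The shared core is a monoterpene-like alcohol carrying a thiosemicarbazide tail; compound 1 `CC1=CC[C@@H]([C@@](C)(O)CCCC(C)(C)NC(=S)NN)CC1` is the plain form. In a functional assay on MCF7 cells (Homo sapiens) for cytotoxicity, read by sulforhodamine B assay (on this read-out higher numbers stand for weaker inhibition of growth and lower numbers for stronger inhibition of growth), compound 1 gives 84200 nM. Compound 2 `CC1=CC[C@@H]([C@@](C)(O)CCCC(C)(C)NC(=S)N/N=C\c2ccccc2)CC1` adds a benzylidene group to the terminal nitrogen, and in this assay compound 2 gives 28700 nM, a step of a 2.9-fold lower number from compound 1 to compound 2 (0.47 log units; beyond the scatter). Compound 3 `CC1=CC[C@@H]([C@@](C)(O)CCCC(C)(C)NC(=S)N/N=C\c2ccc(C)cc2)CC1` carries the same benzylidene with a methyl on the ring. In this assay compound 3 reaches only the limit of > 100000 nM, which is a bound and not a measured number. That makes the steps of an at least 3.4-fold higher number from compound 2 to compound 3 (0.54 log units; beyond the scatter) and an at least 1.1-fold higher number from compound 1 to compound 3 (0.07 log units; that floor lies within the scatter); compound 3 therefore sits at the weak end of the three values, at the limit of > 100000 nM in this assay, at which 1 of the 3 values shown sits.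

Compound 4 `COc1ccc(/C=N\NC(=S)NC(C)(C)CCC[C@](C)(O)[C@@H]2CC=C(C)CC2)cc1` differs from compound 3 by methoxy in place of methyl on an aromatic carbon. Going by the values given here, no measured pair here tests a methoxy, so the only step that bears on it is the one from a bare ring to a methyl ring, which weakened growth inhibition beyond the scatter. A methoxy at the same position is expected to behave similarly, giving a step of roughly an at least 1.2-fold lower number from compound 3 to compound 4 (0.09 log units; that floor lies within the scatter). Compound 4 is therefore estimated at about 80000 nM, within a range from 25000 nM to 200000 nM.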

Compound 4, concentration for total growth inhibition: 94900 nM
Estimate against measurement, compound 4: 1.2-fold (0.07 log units) below; measured number inside the range.
By their numbers in this assay, from the lowest: compound 2; then compounds 1 and 4 (each within the scatter of the next). At a limit, above all of these: compound 3.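

In this assay, methoxy in place of hydrogen on the aromatic ring gives a 3.3-fold higher number from compound 2 to compound 4 (0.52 log units; beyond the scatter), so a measured number now shows that a group on this carbon can cancel the gain of the bare ring, where the methyl gave only a limit. Against the plain form, the methoxy-bearing benzylidene group makes a step of a 1.1-fold higher number from compound 1 to compound 4 (0.05 log units; within the scatter), so this group adds nothing that stands clear of the scatter. Compound 3 stands at a limit, so the swap of methyl for methoxy itself (an at least 1.0-fold lower number from compound 3 to compound 4 (0.02 log units; that floor lies within the scatter)) cannot be read: the limit of > 100000 nM in this assay, at which 1 of the 4 values shown sits.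

Going by these compounds, whether any group on this carbon costs growth inhibition, or only these two, stays open. A fluorine atom or an amine in the same place would help to separate those two readings.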